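Fluorocyclopropyl amide on a bicyclic diamine core

The source may report more compounds than this note shows. Statements on the series, on what has been measured and on what is new or still open speak of the compounds shown alone.

Measured so far:
- compound 1, `CCC(=O)N1CC2CC(C1)N2`: 5900 nM
- compound 2, `O=C(C1CCCC1)N1CC2CC(C1)N2`: 29000 nM
- compound 3, `O=C(C1CC=CC1)N1CC2CC(C1)N2`: 17000 nM

All three compounds share the same bicyclic core and differ only in the group attached to the carbonyl carbon of the amide. In an assay on SH-EP1 cells for agonist activity at Neuronal acetylcholine receptor; alpha4/beta2 (Homo sapiens), read by FLIPR and calcium flux (on this read-out lower numbers stand for an effect already at smaller amounts and higher numbers for an effect only at larger amounts of compound), compound 1 gives 5900 nM, the lowest of the three numbers. Compound 3 gives 17000 nM and compound 2 gives 29000 nM, both beyond the usual scatter from compound 1, so among these three the ethyl amide is the one that acts at the smallest amount.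

Compound 4, `O=C([C@H]1C[C@H]1F)N1CC2CC(C1)N2`, has not yet been measured. It is made from compound 1 by a single change: 2-fluorocyclopropyl in place of ethyl on a carbonyl carbon. The new group keeps the two-carbon reach of ethyl but closes it into a small ring carrying a fluorine, with both stereocentres defined.

For the measured compounds named here, no measured pair shows a step of this kind, so the expectation rests on compound 1 alone. Compound 4 is expected to stay close to compound 1, with the step of a 1.4-fold higher number from compound 1 to compound 4 (0.13 log units; within the scatter) leaning slightly toward a higher number, but not clearly beyond the scatter. The estimate for compound 4 in this assay is 8000 nM, in a range from 2500 nM to 25000 nM.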

Compound 4, half-maximal effective concentration: 1500 nM
Compound 4: middle estimate off by 5.3-fold (0.73 log units), on the high side, and the stated range ends above it.
By their numbers in this assay, from the lowest: compound 4; then compound 1; then compounds 3 and 2 (each within the scatter of the next).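

Replacing ethyl with 2-fluorocyclopropyl on a carbonyl carbon gives a 3.9-fold lower number from compound 1 to compound 4 (0.59 log units; beyond the scatter) in this assay, so this position can take a bigger group than ethyl, one that contains a ring, and the number still falls. The earlier compounds shown here pointed the other way: compound 2 (29000 nM) and compound 3 (17000 nM) also carry a ring on this carbonyl, and compound 1 (5900 nM) stands lowest of the three, so a ring here is not a drawback in every case. For the compounds shown here, nothing measured so far explains why this change lowers the number.

The change brings in a ring and a fluorine at once, so the compounds shown cannot say which of the two accounts for the step; plain cyclopropyl and 2-fluoroethyl on the same carbonyl would pull them apart. They also leave open whether the two defined stereocentres matter, which the other stereoisomers of 2-fluorocyclopropyl would answer, and how a ring carrying something other than fluorine, such as a hydroxyl or an amine, would behave here.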